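The source may hold more compounds than are shown below. What is called first, only, known or untested is meant among the compounds shown, and "the series" means these compounds.

Measured compounds:
- compound 1, `CCCc1ccc(N2C(=O)NC3(CSC4=C3C(=O)c3ncccc3C4=O)C2=O)cc1`: 5 nM
- compound 2, `COc1ccc(N2C(=O)NC3(CSC4=C3C(=O)c3ncccc3C4=O)C2=O)cc1`: 1 nM
- compound 3, `O=C1C2=C(C(=O)c3ncccc31)C1(CS2)NC(=O)N(c2ccc([N+](=O)[O-])cc2)C1=O`: 100 nM

All three share one core and differ only in the group on the aromatic ring that hangs from the nitrogen. In a functional assay on HeLa cells (Homo sapiens) for antiproliferative activity, read by MTT assay, with a stated time of 96 h (on this read-out higher numbers stand for weaker inhibition and lower numbers for stronger inhibition), compound 1 stands second highest of the three numbers. Its nearest neighbour is compound 2, reached by a 5.0-fold lower number from compound 1 to compound 2 (0.70 log units; beyond the scatter). Its furthest is compound 3, reached by a 20-fold higher number from compound 1 to compound 3 (1.30 log units; beyond the scatter); between those two, a 100-fold higher number from compound 2 to compound 3 (2.00 log units; beyond the scatter).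

Compound 4 is `O=C1C2=C(C(=O)c3ncccc31)C1(CS2)NC(=O)N(c2ccccc2)C1=O`. It differs from compound 1 in one place: hydrogen in place of propyl on an aromatic carbon.

Going by the values given here, no measured step removes a group in favour of bare hydrogen, so the bearing of the three steps is indirect. Swapping propyl for methoxy gave a modest gain; swapping it for nitro gave a large loss. The three numbers therefore show that this position tolerates change, yet can shift potency strongly. Taking hydrogen as a neutral middle case, a small-to-modest rise in the number is expected for compound 4, and the step of a 2.0-fold higher number from compound 1 to compound 4 (0.30 log units; within the scatter) is the estimated size. Compound 4 is expected to give about 10 nM, within a range from 2 nM to 50 nM.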

Compound 4, half-maximal inhibitory concentration: 3 nM
Compound 4: middle estimate off by 3.3-fold (0.52 log units), on the high side; low and high end bracket the measured number.
By their numbers in this assay, from the lowest: compound 2; then compounds 4 and 1 (each within the scatter of the next); then compound 3.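

Going by these compounds alone, compound 4 supplies the bare ring that the earlier compounds lacked, giving a baseline for this position in this assay. Hydrogen in place of propyl makes no difference that rises out of the scatter (a 1.7-fold lower number from compound 1 to compound 4 (0.22 log units; within the scatter)), so going from 4-propylphenyl to phenyl leaves the number effectively unchanged, and the propyl chain is not needed for activity in this set. Against this baseline, the other two groups can be read separately: hydrogen in place of nitro shows that the large loss belongs to nitro (a 33-fold lower number from compound 3 to compound 4 (1.52 log units; beyond the scatter)), while hydrogen in place of methoxy shows that methoxy holds a modest edge over the bare ring (a 3.0-fold higher number from compound 2 to compound 4 (0.48 log units; beyond the scatter)), and nothing shown gives a cause for either shift.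

The compounds shown leave open whether an amine, a hydroxyl or a chloro group at this place would behave more like methoxy or more like nitro. They also leave open how far the tolerance for carbon chains extends, for instance to a longer chain such as hexyl or to a second phenyl ring.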